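A few compounds are considered here, and "the series" means these few. Any claim that something is new, unique, unknown or untested is made for them only; others in the source may bear on it.

Measured so far in a physicochemical assay for lipophilicity, read by HPLC, tested at 5 mM; a lower number here means a more polar compound, a higher number a more lipophilic compound:
compound 1 `CC(Oc1ccc(Oc2ccc(C(F)(F)F)cc2)cc1)C(=O)Cn1nnc(-c2ccccc2)n1` gives 6.2
compound 2 `CC(Oc1ccc(Oc2ccc(C(F)(F)F)cc2)cc1)C(=O)Cn1nnc(-c2ccc(Cl)cc2)n1` gives 7
compound 3 `COC(=O)c1ccc(-c2nnn(CC(=O)C(C)Oc3ccc(Oc4ccc(Cl)cc4)cc3)n2)cc1` gives 6.1

Compound 3 stands lowest of the three numbers in this assay. Its nearest neighbour is compound 1, which sits only within the scatter of it, while compound 2 lies beyond the scatter above it. Compound 1 and compound 3 differ from each other in two places, so their two values are noted side by side without a step being drawn between them. Going by the values given here, the single measured step with one change, a number 0.80 log units higher from compound 1 to compound 2 (beyond the scatter), concerns the ring attached to the tetrazole, not the phenoxy ring.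

Compound 4 `COC(=O)c1ccc(-c2nnn(CC(=O)C(C)Oc3ccc(Oc4ccc(C(F)(F)F)cc4)cc3)n2)cc1` differs from compound 3 by trifluoromethyl in place of chloro on an aromatic carbon. Among the compounds with values here, no measured pair exchanges chloro for trifluoromethyl at any position, so the expectation rests on the modest size of the one substituent step seen, and on the fact that the change here is an exchange between two groups rather than an addition. The step from compound 3 to compound 4 is therefore expected to be small, a number 0.20 log units higher from compound 3 to compound 4 (within the scatter), and not beyond the scatter. Compound 4 is estimated at 6.3 in this assay, with a range from 5.8 to 6.8.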

Compound 4, partition coefficient: 6.2
Estimate against measurement, compound 4: 0.10 log units above; the measured number falls inside the stated range.
By their numbers in this assay, from the lowest: compounds 3, 1 and 4 (each within the scatter of the next); then compound 2.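

In this assay, going by these compounds alone, the only measured exchange of chloro for trifluoromethyl, 4-chlorophenoxy to 4-(trifluoromethyl)phenoxy, gives a number 0.10 log units higher from compound 3 to compound 4 (within the scatter) and so does not separate the two groups at this position, with methoxycarbonyl held constant at the other substituted place. Compound 4 also adds a reading at that other place, where methoxycarbonyl in place of hydrogen gives no change at the digits printed from compound 1 to compound 4 (within the scatter) and methoxycarbonyl in place of chloro gives a number 0.80 log units lower from compound 2 to compound 4 (beyond the scatter) and, on compound 1, compound 2 and compound 4 alone, chloro stands apart there while hydrogen and methoxycarbonyl do not separate. No measurement in hand accounts for these numbers.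

On these data alone, whether chloro and trifluoromethyl would also stay together with hydrogen or chloro at the other substituted place remains open, since the pair here carries methoxycarbonyl there. Also open, as far as these compounds go, is how a carboxylic acid, a primary amide or an amine in place of methoxycarbonyl, or fluoro or a longer alkyl chain in place of trifluoromethyl, would read in this assay on this core.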